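Swapping methoxy for dimethylamino on the shared core

A few compounds are considered here, and "the series" means these few. Any claim that something is new, unique, unknown or untested is made for them only; others in the source may bear on it.

Of the compounds shown here, three sharing one core have been measured in an ADME assay on microsomes from liver (Homo sapiens) for metabolic stability, with a stated time of 10 min; a lower number here means that less of the compound is left, a higher number that more of the compound is left. Compound 1 `COc1ccc(Nc2nc(Cl)cn([C@H](C)C3CC3)c2=O)c(C)n1` gives 60%. Compound 2 `COc1ccc(Nc2nc(Cl)cn([C@H](C)C3CC3)c2=O)c(OC)n1` gives 25%, and compound 3 `COc1nc(C)c(Nc2nc(Cl)cn([C@H](C)C3CC3)c2=O)cc1C` gives 55%. Compound 3 thus stands second highest of the three numbers; it is within the scatter of compound 1 and clearly apart from compound 2. The step of a number 35 percentage points lower from compound 1 to compound 2 (beyond the scatter) shows that a change of the group on that ring carbon can move this read-out a long way, whereas the step of a number 5 percentage points lower from compound 1 to compound 3 (within the scatter) shows a change elsewhere on the ring that made no real difference.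

Compound 4 `Cc1cc(Nc2nc(Cl)cn([C@H](C)C3CC3)c2=O)c(C)nc1N(C)C` differs from compound 3 by dimethylamino in place of methoxy on an aromatic carbon. Going by the values given here, no measured step tests this exact swap, so the direction is uncertain. Because the step of a number 35 percentage points lower from compound 1 to compound 2 (beyond the scatter) was large when the group at this position was exchanged, a sizeable move is possible, and a modest fall is expected, a number 15 percentage points lower from compound 3 to compound 4 (beyond the scatter). Compound 4 is therefore estimated at 40%, within 15% to 65%.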

Compound 4, percent of the compound remaining: 29%
Estimate against measurement, compound 4: 11 percentage points above, within the range that was stated.
By their numbers in this assay, from the lowest: compounds 2 and 4 (each within the scatter of the next); then compounds 3 and 1 (each within the scatter of the next).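

All three earlier compounds carry methoxy on this aromatic carbon next to the ring nitrogen, so they could not show whether the group there matters. The swap to dimethylamino shows that it does: in this assay, the change is beyond the usual scatter (a number 26 percentage points lower from compound 3 to compound 4 (beyond the scatter)), so this position is not a silent one for this read-out. Nothing measured here explains why less of compound 4 remains.

Going by these compounds, this is a single swap, so it remains open whether any nitrogen group at this carbon would give a similar number or whether the result is particular to dimethylamino. A smaller amine such as methylamino, a ring amine such as morpholine, or a longer ether such as ethoxy at the same carbon would help separate these possibilities.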